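The source may report more compounds than this note shows. Statements on the series, on what has been measured and on what is new or still open speak of the compounds shown alone.

Measured so far in a functional assay on HCT-116 cells (Homo sapiens) for cytotoxicity, read by MTT assay, with a stated time of 72 h; on this read-out higher numbers stand for weaker inhibition and lower numbers for stronger inhibition
- compound 1 `Oc1ccc(C2C/C(=N\NC(=S)N3CCOCC3)c3ccc(O)cc3O2)cc1` gives 63500 nM
- compound 2 `CC(C)(C)NC(=S)N/N=C1\CC(c2ccc(O)cc2)Oc2cc(O)ccc21` gives 25900 nM
- compound 3 `Oc1ccc(C2C/C(=N\NC(=S)N3CCCCC3)c3ccc(O)cc3O2)cc1` gives 50900 nM

Compound 1 stands at the high end of these numbers, which is the weak end of the read-out, although compound 3 cannot be told apart from it. Compound 4 `CCCNC(=S)N/N=C1\CC(c2ccc(O)cc2)Oc2cc(O)ccc21` has not yet been measured. It differs from compound 1 as follows: propylamino in place of morpholin-4-yl on a thiocarbonyl carbon.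

Two measured changes also remove morpholin-4-yl. Piperidin-1-yl, which is again a ring, gives a 1.2-fold lower number from compound 1 to compound 3 (0.10 log units; within the scatter) and so offers little guidance. The group in compound 2, (tert-butyl)amino, resembles propylamino more closely in having no ring, and it gives a 2.5-fold lower number from compound 1 to compound 2 (0.39 log units; beyond the scatter) as a modest change. These two replacements do not separate clearly from each other, with a 2.0-fold higher number from compound 2 to compound 3 (0.29 log units; within the scatter) as the measured gap. Three compounds are a thin basis, so only a small drop is likely. The step expected in this assay is a 2.0-fold lower number from compound 1 to compound 4 (0.30 log units; within the scatter) as a rough guide. For compound 4 the estimated value is 32000 nM, with an expected range from 14000 nM to 60000 nM overall.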

Compound 4, half-maximal inhibitory concentration: 54000 nM
For compound 4 the middle estimate is 1.7-fold (0.23 log units) below the measured one, within the range that was stated.
By their numbers in this assay, from the lowest: compounds 2, 3, 4 and 1 (each within the scatter of the next, the first and the last beyond it).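

In this assay, propylamino in place of morpholin-4-yl on the thiocarbonyl carbon gives a 1.2-fold lower number from compound 1 to compound 4 (0.07 log units; within the scatter) and propylamino in place of piperidin-1-yl gives a 1.1-fold higher number from compound 3 to compound 4 (0.03 log units; within the scatter); on these numbers, this open-chain group cannot be told apart from either ring. Compound 2 also has no ring and keeps a hydrogen on the amide-type nitrogen, yet propyl in place of tert-butyl there gives a 2.1-fold higher number from compound 2 to compound 4 (0.32 log units; beyond the scatter), a modest step, so having no ring and having that hydrogen do not on their own go with the lower number of compound 2. Even so, compound 2 stands apart only from compound 1 and compound 4, as its gap to compound 3 lies within the scatter, and no measurement available here explains the difference between tert-butyl and propyl.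

Going by these compounds, it remains open whether the branched shape of tert-butyl matters at this position, a question that isopropylamino, with its shorter branched chain, or butylamino, with its longer straight chain, could help to settle. The compounds shown also leave open how a plain unsubstituted amino group or a ring-bearing amine such as cyclohexylamino would compare with these four groups.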